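Swapping ethyl for cyclopropyl: what to expect of compound 4

The compounds below may be only part of what the source reports. "The series", "measured", "known", "first", "only" and "open" are said of these compounds alone.

In an ADME assay on S9 fraction from liver (Rattus norvegicus, strain Sprague-Dawley) for metabolic stability, read by LC-MS, using NADPH, with stated times of 5 min and 60 min, tested at 5 uM (on this read-out lower numbers stand for a less stable compound and higher numbers for a more stable compound), compound 3 `CCc1ccc(COc2ccc(C3CN(C(=O)c4cc(COCC(CO)(CO)CO)ccn4)C3)cc2OC)cc1` gives 58%. Compound 1 `COc1cc(C2CN(C(=O)c3cc(OC[C@@H](O)CO)ccn3)C2)ccc1OCc1ccc(C2CC2)cc1` gives 61%, within the usual scatter of compound 3, while compound 2 `COc1cc(C2CN(C(=O)c3cc(OCCCC(=O)O)ccn3)C2)ccc1OCc1ccc(C2CC2)cc1` stands well clear of both at 100%.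

Compound 4 `COc1cc(C2CN(C(=O)c3cc(COCC(CO)(CO)CO)ccn3)C2)ccc1OCc1ccc(C2CC2)cc1` differs from compound 3 in one group: cyclopropyl in place of ethyl on an aromatic carbon. Cyclopropyl takes the place of ethyl on an aromatic carbon, para to a large group. Within the data shown here, no measured pair makes this exchange. Among the measured compounds shown here, the only measured step, a number 39 percentage points higher from compound 1 to compound 2 (beyond the scatter), is large, but it concerns a different group and so offers no direct guide. Compound 1 and compound 2 both carry the cyclopropyl group, yet their values lie far apart, so its presence alone does not settle the number.

With no direct evidence of a shift, the expected change in this assay is a number 2 percentage points higher from compound 3 to compound 4 (within the scatter), which is not expected to exceed the scatter. The estimated value for compound 4 is 60%, with an expected range from 42% to 80%.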

Compound 4, percent of the compound remaining: 73%
For compound 4 the middle estimate is 13 percentage points below the measured one, within the range that was stated.
By their numbers in this assay, from the lowest: compounds 3 and 1 (each within the scatter of the next); then compound 4; then compound 2.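

In this assay the exchange of 4-ethylbenzyl for 4-cyclopropylbenzyl gives a number 15 percentage points higher from compound 3 to compound 4 (beyond the scatter) and so shows that this aromatic carbon, para to a large group, can change the number while the rest of the molecule stays fixed. With cyclopropyl held constant, the other side chain matters too: one exchange gives a number 12 percentage points higher from compound 1 to compound 4 (beyond the scatter) and another gives a number 27 percentage points lower from compound 2 to compound 4 (beyond the scatter), placing the (3-hydroxy-2,2-bis(hydroxymethyl)propoxy)methyl compound above the 2,3-dihydroxypropoxy compound and under the 3-carboxypropoxy compound. No measurement here explains either shift.

On these data alone, it remains open whether cyclopropyl would give a similar rise alongside the 3-carboxypropoxy or 2,3-dihydroxypropoxy chains. As far as these compounds go, how isopropyl or trifluoromethyl would compare on the same aromatic carbon also remains unknown.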